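The source may hold more compounds than are shown below. What is called first, only, known or untested is meant among the compounds shown, and "the series" means these compounds.

Compound 1 `COc1cc(-c2nn(-c3ccccc3)cc2C(=O)/C=C\Nc2ccc(Cl)cc2)cc(OC)c1OC` gives 30200 nM in an ADME assay on HaCaT cells (Homo sapiens) for antiproliferative activity, read by MTT assay, with a stated time of 48 h; a lower number here means a stronger inhibitor, a higher number a weaker inhibitor. Compound 2 `COc1cc(-c2nn(-c3ccccc3)cc2C(=O)/C=C\Nc2ccc(C(F)(F)F)cc2)cc(OC)c1OC` reaches only a limit of this assay, > 50000 nM. Within the data shown here, the one step between them, trifluoromethyl in place of chloro on an aromatic carbon, is an at least 1.6-fold higher number from compound 1 to compound 2 (0.21 log units; that floor lies within the scatter); its true size stays open because compound 2 sits at the limit of > 50000 nM in this assay, at which 1 of the 2 values shown sits. Compound 3 `COc1cc(N/C=C\C(=O)c2cn(-c3ccccc3)nc2-c2cc(OC)c(OC)c(OC)c2)cc(OC)c1OC` differs from compound 2 by 3,4,5-trimethoxyphenyl in place of 4-(trifluoromethyl)phenyl on an amine nitrogen. Among the measured compounds shown here, no measured step covers this change, and compound 2 is known only as a limit, so the change is estimated as a step of an at least 1.2-fold lower number from compound 2 to compound 3 (0.09 log units; that floor lies within the scatter) with an uncertain direction. Compound 3 is expected near 40000 nM, within 12000 nM to 120000 nM.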

Compound 3, half-maximal inhibitory concentration: 20900 nM
Compound 3: middle estimate off by 1.9-fold (0.28 log units), on the high side, within the range that was stated.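

On the amine nitrogen, 3,4,5-trimethoxyphenyl in place of 4-(trifluoromethyl)phenyl gives an at least 2.3-fold lower number from compound 2 to compound 3 (0.37 log units; beyond the scatter) in this assay, the first step shown at this position that lies beyond the scatter. On these data alone, the value of compound 2 is a limit, and the true size of that step stays open: the limit of > 50000 nM in this assay, at which 1 of the 3 values shown sits. Set against 4-chlorophenyl, the same group gives a 1.4-fold lower number from compound 1 to compound 3 (0.16 log units; within the scatter), leaving compound 1 and compound 3 indistinguishable here.

As far as these compounds go, it remains open whether all three methoxy groups matter. A plain phenyl, or a phenyl carrying an amine or a carboxylic acid, on this nitrogen could still behave differently.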